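Replacing the Pentyl Chain with a Thiophene Ring

The source may hold more compounds than are shown below. What is called first, only, known or untested is meant among the compounds shown, and "the series" means these compounds.

Going by the values given here, compound 1 `CCCCCC(=O)Nc1ccc2[nH]cc(C3CCN(C)CC3)c2n1` gives the lowest of the two numbers so far in an assay for binding affinity to 5-hydroxytryptamine receptor 1F (Homo sapiens), read by radioligand binding (on this read-out higher numbers stand for weaker inhibition and lower numbers for stronger inhibition), at 13 nM. Its nearest neighbour is compound 2 `CCCCCCCC(=O)Nc1ccc2[nH]cc(C3CCN(C)CC3)c2n1`, which in this assay gives 20 nM; the step of a 1.5-fold higher number from compound 1 to compound 2 (0.19 log units; within the scatter) stays within the scatter. Compound 3 `CN1CCC(c2c[nH]c3ccc(NC(=O)c4cccs4)nc23)CC1` carries thiophen-2-yl in place of pentyl on a carbonyl carbon. Among the compounds with values here, the one measured step concerns only the length of the chain and says nothing about an aromatic ring in its place, so no firm direction can be drawn; the step of a 1.2-fold higher number from compound 1 to compound 3 (0.06 log units; within the scatter) is expected to stay near the scatter. Compound 3 is therefore estimated at 15 nM, with a range from 4 nM to 60 nM.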

Compound 3, inhibition constant: 7.1 nM
Estimate against measurement, compound 3: 2.1-fold (0.32 log units) above; the range from low to high includes it.
By their numbers in this assay, from the lowest: compounds 3, 1 and 2 (each within the scatter of the next, the first and the last beyond it).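

In this assay, this carbonyl carbon takes an aromatic ring as well as a saturated chain: thiophen-2-yl in place of pentyl gives a 1.8-fold lower number from compound 1 to compound 3 (0.26 log units; within the scatter) and so cannot be told apart from pentyl. Set against heptyl, the same ring gives a 2.8-fold lower number from compound 2 to compound 3 (0.45 log units; beyond the scatter) and this modest step is the first one here to pass the scatter. Nothing available explains this result. From the compounds shown here alone, whether a phenyl or furan-2-yl ring on this carbonyl carbon would read the same remains open, and so does whether the ring sulfur matters. A shorter chain such as propyl is also an open case.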